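The compounds below may be only part of what the source reports. "The series", "measured", "known", "first", "only" and "open" are said of these compounds alone.

Measured compounds in a functional assay on HeLa cells (Homo sapiens) for cytotoxicity, read by sulforhodamine B assay, with a stated time of 48 h; on this read-out higher numbers stand for weaker inhibition and lower numbers for stronger inhibition:
- compound 1 `CC1=C(/C=C/C(=O)/C=C/c2ccc(Cl)cc2)C(C)(C)CCC1`: 33200 nM
- compound 2 `COc1ccc(/C=C/C(=O)/C=C/C2=C(C)CCCC2(C)C)cc1`: 15700 nM

Among the compounds with values here, on the numbers so far compound 1 stands highest of the two, with compound 2 as the only neighbour; the step of a 2.1-fold lower number from compound 1 to compound 2 (0.33 log units; beyond the scatter) is the one change in the shared core measured to date.

Compound 3 `CC1=C(/C=C/C(=O)/C=C/c2ccccc2Cl)C(C)(C)CCC1` differs from compound 1 in one place: 2-chlorophenyl in place of 4-chlorophenyl on a double-bonded chain carbon bound to a double-bonded chain carbon. The chlorine stays, the aromatic ring stays, and only its point of attachment on the ring moves. Within the data shown here, no measured pair bears directly on this kind of change: the sole measured step, a 2.1-fold lower number from compound 1 to compound 2 (0.33 log units; beyond the scatter), exchanges one group for another at the same place and says nothing about moving a group around the ring. Among the measured compounds shown here, it shows only that a single change on that ring can shift this assay by a modest amount. With no guide for the present change, the expectation is a step of about no size beyond the scatter, in either direction, and compound 3 is estimated close to compound 1, the expected step being a 1.1-fold lower number from compound 1 to compound 3 (0.04 log units; within the scatter). Compound 3 is therefore expected to give about 30000 nM, within 12000 nM to 75000 nM.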

Compound 3, half-maximal inhibitory concentration: 21800 nM
Estimate against measurement, compound 3: 1.4-fold (0.14 log units) above, within the range that was stated.
By their numbers in this assay, from the lowest: compounds 2, 3 and 1 (each within the scatter of the next, the first and the last beyond it).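

In this assay, moving the chlorine around the ring gives a 1.5-fold lower number from compound 1 to compound 3 (0.18 log units; within the scatter), so 2-chlorophenyl and 4-chlorophenyl cannot be told apart at this place, on a double-bonded chain carbon bound to a double-bonded chain carbon. Within the data shown here, this is the first measured pair in which the ring and its chlorine both stay and only the point of attachment differs, whereas the earlier step exchanged one group for another; here, two groups with the same atoms lie within the scatter of each other, and the position of the chlorine on the ring has no resolved effect in this pair. No measurement on hand accounts for this result.

On these data alone, it remains open whether a group of another kind on this ring, such as an amine or a carboxylic acid in place of the chlorine, would give a step beyond the scatter in this assay. Also open, as far as these compounds go, is whether the methoxy group of compound 2 would behave as the chlorine does when its point of attachment on the ring moves, and whether a longer chain between the ring and the rest of the shared core would matter more than either change.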